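A few compounds are considered here, and "the series" means these few. Any claim that something is new, unique, unknown or untested is made for them only; others in the source may bear on it.

Compound 1 `Nc1ccc(-c2cc(=O)c3c(N)c(F)cc(F)c3o2)cc1F`: > 100000 nM
Compound 2 `Nc1ccc(-c2cc(=O)c3c(N)c(F)c(Br)c(F)c3o2)cc1F`: > 100000 nM

Both compounds were tested in a functional assay on HeLa cells (Homo sapiens) for cytotoxicity, read by neutral red uptake, with a stated time of 3 days (on this read-out higher numbers stand for weaker inhibition and lower numbers for stronger inhibition), and neither gave a number. Compound 1 gives > 100000 nM, which is a limit of the assay. Compound 2 gives > 100000 nM, which is also a limit. Compound 2 therefore has no numerical position, and the measured series consists only of the limit of > 100000 nM in this assay, at which 2 of the 2 values shown sit.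

Compound 3 `[N-]=[N+]=Nc1c(F)c(N)c2c(=O)cc(-c3ccc(N)c(F)c3)oc2c1F` has azido in place of bromo on an aromatic carbon, ortho to two fluoro groups: azido in place of bromo on an aromatic carbon. Within the data shown here, the one measured step bearing on this carbon is a step that the two limits leave unreadable from compound 1 to compound 2, with bromo in place of hydrogen on an aromatic carbon. That step has no readable size, so it offers no magnitude to carry over to the new group. Among the measured compounds shown here, with no measured step to suggest a shift in either direction, no change beyond the scatter is expected in this assay, and compound 3 may well be reported as a limit too. The expected step is a number no higher from compound 2 to compound 3 (the limit leaves the size open). For compound 3 the estimated value is 100000 nM, within an expected range of 30000 nM to 200000 nM.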

Compound 3, half-maximal inhibitory concentration: 1200 nM
Estimate against measurement, compound 3: 83-fold (1.92 log units) above; the measured number lies below the stated range.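

Azido in place of bromo on this aromatic carbon, ortho to two fluoro groups, gives an at least 83-fold lower number from compound 2 to compound 3 (1.92 log units; beyond the scatter), and azido in place of hydrogen on the same carbon gives an at least 83-fold lower number from compound 1 to compound 3 (1.92 log units; beyond the scatter). The earlier step from hydrogen to bromo could not be read, so it gave no sign that the group on this carbon made any difference in this assay, whereas compound 3 shows that a change here can bring a measurable number. Compound 3 stands apart as the only compound of the three with a number, while the other two share a limit of the assay: the limit of > 100000 nM in this assay, at which 2 of the 3 values shown sit.

Both steps start from a limit, so their true size remains unknown, and the compounds shown cannot tell how much of the azido group is needed for the drop. On these data alone, it also remains open whether a nitrile, a methoxy group or a longer chain on the same carbon would give a number in this range, or whether azido stands alone among the groups placed there.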